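The compounds below may be only part of what the source reports. "The series", "measured", "known", "first", "only" and "open" are said of these compounds alone.

Measured compounds:
compound 1, `N=C(N)NCCC[C@H](NC(=O)CN(c1nc(Cl)nc2[nH]cnc12)C1CC1)C(=O)O` — in a functional assay on the whole organism (Tail, strain ICR) with Mus musculus as the target, in the tail flick test, with a stated time of 120 min, at a dose of 6.25 umol/kg by the oral route (a higher number here means a stronger effect of the compound at the dose given, a lower number a weaker effect), compound 1 gives 9.52%
compound 2, `NCCCC[C@H](NC(=O)CN(c1nc(Cl)nc2[nH]cnc12)C1CC1)C(=O)O` — in this assay compound 2 gives 7.05%

Both compounds share the same core and differ only in the side chain. The step of a number 2.5 percentage points lower from compound 1 to compound 2 (within the scatter) lies within the scatter, so the two numbers are best read as the same small effect, and compound 2 cannot be set apart from compound 1 on these numbers.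

Compound 3, `CC(C)C[C@H](NC(=O)CN(c1nc(Cl)nc2[nH]cnc12)C1CC1)C(=O)O`, has not yet been measured. It differs from compound 2 in the change (isopropyl in place of 3-aminopropyl on a saturated chain carbon, two bonds along the chain from an amide-type nitrogen and a carbonyl carbon). Going by the values given here, the one measured step that touches the same part of the molecule is a number 2.5 percentage points lower from compound 1 to compound 2 (within the scatter), which swapped one nitrogen-containing group for another on the side chain and left the read-out essentially unchanged. The change to compound 3 removes the nitrogen altogether, which is a larger change than that step, but nothing measured here points to a shift beyond the scatter. Compound 3 is therefore expected to stay close to compound 2, with the step of a number 2 percentage points higher from compound 2 to compound 3 (within the scatter) expected to lie within the scatter. The estimate for compound 3 in this assay is 9%, in the range 0% to 22%.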

Compound 3, a percentage reported as activity, at one dose (the size of the read-out at that dose, not a potency): 9.44%
For compound 3 the middle estimate is 0.4 percentage points below the measured one, and the stated range covers the measured number.
By their numbers in this assay, from the lowest: compounds 2, 3 and 1 (each within the scatter of the next).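

Isopropyl in place of 3-aminopropyl on this saturated chain carbon gives a number 2.4 percentage points higher from compound 2 to compound 3 (within the scatter) in this assay and so removes the nitrogen from the side chain altogether, which the earlier step could not do because it swapped one nitrogen-bearing chain for another. The all-carbon group of compound 3 in place of the larger side chain of compound 1 gives a number 0.1 percentage points lower from compound 1 to compound 3 (within the scatter) and likewise stays inside the scatter, so at this one dose and time the read-out does not depend on whether a nitrogen is present in the side chain of these three compounds. What lies behind this flat reading cannot be said from the information at hand.

The compounds shown leave open whether a side chain bearing a carboxylic acid or a phenyl ring at this position would move the read-out beyond the scatter. They also leave open whether a change on the shared core, away from this side chain, would matter more than any of the side chain changes seen so far.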